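The source may hold more compounds than are shown below. What is called first, only, known or untested is meant among the compounds shown, and "the series" means these compounds.

Among the measured compounds shown here, in a physicochemical assay for lipophilicity, read by HPLC, in phosphate buffer, measured as octanol-water partition, with a stated time of 1 h, at pH 7.4 (on this read-out lower numbers stand for lower lipophilicity and higher numbers for higher lipophilicity), three related compounds have numbers so far. Compound 2 (`CC1=C[C@@](C)(c2cc(NC(=O)c3ccc(C#N)cn3)ccc2F)N=C(N)O1`) gives 2.2, compound 3 (`C[C@@]1(c2cc(NC(=O)c3ccc(C#N)cn3)ccc2F)C=C(CF)OC(N)=N1`) gives 2.3 and compound 1 (`C[C@@]1(c2cc(NC(=O)c3ncc(C#N)cc3Cl)ccc2F)C=C(CF)OC(N)=N1`) gives 2.5, which places compound 2 within the scatter of both others. Compound 4 (`CC1=COC(N)=N[C@]1(C)c1cc(NC(=O)c2ccc(C#N)cn2)ccc1F`) has not been measured yet. It holds the same atoms as compound 2, joined differently: a group of 9 heavy atoms (6 carbon, 2 nitrogen, 1 oxygen; one six-membered non-aromatic ring with 2 hetero atoms) in place of a group of 9 heavy atoms (6 carbon, 2 nitrogen, 1 oxygen; one six-membered non-aromatic ring with 2 hetero atoms), on an aromatic carbon. For the measured compounds named here, no measured pair shows this kind of change, so the evidence is only indirect. Hydrogen in place of chloro on an aromatic carbon gave a number 0.20 log units lower from compound 1 to compound 3 (within the scatter), and fluoro in place of hydrogen on a saturated chain carbon gave a number 0.10 log units higher from compound 2 to compound 3 (within the scatter). Both steps are small and stay within the scatter. The new change adds and removes no atom, so no step beyond the scatter is expected in this assay, and neither direction is favoured. The expected outcome is no change at the digits printed from compound 2 to compound 4 (within the scatter). For compound 4 the estimated value is 2.2, with a likely range from 1.8 to 2.6.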

Compound 4, distribution coefficient: 1.5
For compound 4 the middle estimate is 0.70 log units above the measured one; measured number outside the range, below it.
By their numbers in this assay, from the lowest: compound 4; then compounds 2, 3 and 1 (each within the scatter of the next).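

In this assay the exchange of one ring group for another built from the same atoms gives a number 0.70 log units lower from compound 2 to compound 4 (beyond the scatter) and is the only step shown that lies beyond the scatter. The two groups match in heavy atoms, double bonds, hydrogen-bond donors and acceptors, net charge and defined stereocentres, so these counts alone do not reveal a difference at this place on the aromatic carbon; how the ring atoms are joined is enough to shift the number. No measurement shown accounts for this step.

The compounds leave open whether a similar step appears when the amide partner carries chloro, as in compound 1, or when a trifluoromethyl group or an ethyl chain stands on the ring. A single pair also cannot show whether this step holds across other related compounds.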